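Thiophen-2-yl for 3-Bromopropyl: an Expected Cytotoxicity Reading

This account rests on a few compounds, and the source may have more. Where it says the series, first, only, none or still open, it means among the compounds named here.

Compound 1 `BrCCCc1ccc(-c2ccc(-c3ccc(CCCBr)s3)s2)s1`: > 200000 nM
Compound 2 `NCCCCc1ccc(CCCCN)s1`: "not determined" (no result reported)
Compound 3 `O=C(NCCCCc1ccc(-c2ccc(-c3ccc(CCCCNC(=O)c4cc(F)cc(C(F)(F)F)c4)s3)s2)s1)c1cc(F)cc(C(F)(F)F)c1`: "not determined" (no result reported)

Three compounds have so far been examined in an ADME assay on MDCK cells (Canis lupus familiaris) for cytotoxicity, read by MTT assay, with a stated time of 2 days; on this read-out lower numbers stand for higher toxicity in this test and higher numbers for lower toxicity in this test. For compound 1 the outcome is only a limit of the assay, > 200000 nM, and not a single number. Of the three entries shown, (the limit of > 200000 nM in this assay, at which 1 of the 3 values shown sits). In this assay compound 2 gives "not determined" (no result reported). In this assay compound 3 likewise gives "not determined" (no result reported). So compound 1 is the one compound with any reading at all, and that reading is a limit rather than a value; no pair of measured compounds differing in a single place is available, and therefore no measured step exists to guide expectations.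

The next compound is compound 4 `BrCCCc1ccc(-c2ccc(-c3ccc(-c4cccs4)s3)s2)s1`. Compared with compound 1 the change is thiophen-2-yl in place of 3-bromopropyl on an aromatic carbon. Within the data shown here, with no measured step to draw on, the only anchor is the limit reached by compound 1 in this assay. The step of a number no higher from compound 1 to compound 4 (the limit leaves the size open) is expected to be none beyond the scatter, with the reading most likely to end again at a limit. Compound 4 is accordingly expected to give 200000 nM, within 100000 nM to 400000 nM.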

Compound 4, half-maximal cytotoxic concentration: > 200000 nM
Compound 4: no number, only a limit; the forecaster's own chance of this, stated with the estimate: 75%; the middle value lies on the limit itself.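

In this assay, among these compounds, compound 1 and compound 4 each give only a limit, not a number, so no step between them can be read. What the compounds shown leave open is the actual concentration at which either one harms these cells, and whether thiophen-2-yl in place of 3-bromopropyl makes any difference to it.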